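A few compounds are considered here, and "the series" means these few. Any claim that something is new, unique, unknown or untested is made for them only; others in the source may bear on it.

Of the compounds shown here, three have been measured so far in an assay on isolated protein for inhibition of protein kinase C theta type (Homo sapiens), read by TR-FRET, with a stated time of 2 h; on this read-out lower numbers stand for stronger inhibition and higher numbers for weaker inhibition. Compound 1 `N#Cc1cnc(NCc2cnccc2C(F)(F)F)cc1N[C@H]1CC[C@@H](C(N)=O)CC1` gives 7 nM, compound 2 `CN(C)C(=O)[C@H]1CC[C@@H](Nc2cc(NCc3cnccc3C(F)(F)F)ncc2C#N)CC1` gives 38 nM, and compound 3 `N#Cc1cnc(NCc2cncnc2C(F)(F)F)cc1N[C@H]1CC[C@@H](O)CC1` gives 450 nM, the highest of the three numbers and therefore the weakest inhibition among them. Among the compounds with values here, the only single-point step available, a 5.4-fold higher number from compound 1 to compound 2 (0.73 log units; beyond the scatter), concerns the amide and says nothing about the aromatic ring. Compound 4 `COc1ncncc1CNc1cc(N[C@H]2CC[C@@H](O)CC2)c(C#N)cn1` differs from compound 3 by methoxy in place of trifluoromethyl on an aromatic carbon. Within the data shown here, no measured step bears on this exchange, so the expectation rests on the structural change alone, and a modest weakening beyond the scatter is estimated, a 2.0-fold higher number from compound 3 to compound 4 (0.30 log units; within the scatter). For compound 4 the expected value in this assay is 900 nM, with a range from 150 nM to 5000 nM.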

Compound 4, half-maximal inhibitory concentration: 800 nM
Beside the measured number, compound 4's estimate is 1.1-fold (0.05 log units) above it, within the range that was stated.
By their numbers in this assay, from the lowest: compound 1; then compound 2; then compounds 3 and 4 (each within the scatter of the next).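

In this assay, methoxy in place of trifluoromethyl on this aromatic carbon gives a 1.8-fold higher number from compound 3 to compound 4 (0.25 log units; within the scatter) and so the two compounds cannot be told apart, even though the two groups differ in heavy atoms and hydrogen-bond acceptors. No supporting measurement is available to explain this result. Still open, from the compounds shown here alone, is whether another group on this carbon, such as an amine, a chlorine atom or a longer ether chain, would move the number beyond the scatter. The compounds shown also leave open whether this exchange would read the same in a compound with the carbonyl side chain of compound 1.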